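The source may hold more compounds than are shown below. What is called first, only, known or untested is meant among the compounds shown, and "the series" means these compounds.

Compound 1 `Cc1ccc(-c2c(C)nc(NC(=O)NC3CCOCC3)c(C)c2C(OC(C)(C)C)C(=O)O)cc1C` and compound 2 `Cc1nc(NC(=O)NC2CCCCC2)c(C)c(C(OC(C)(C)C)C(=O)O)c1-c1ccc2c(c1)NCCO2` have both been measured in an ADME assay on MT4 cells (Homo sapiens) for cytotoxicity, read by MTT assay; a lower number here means that less compound is tolerated, a higher number that more compound is tolerated. In this assay compound 1 gives 29000 nM, which is the lowest of the two numbers on record, while compound 2 gives 30000 nM, a gap that lies within the scatter, so the two stand level and nothing separates them. Compound 3 `Cc1ccc(-c2c(C)nc(NC(=O)NC3CCCCCC3)c(C)c2C(OC(C)(C)C)C(=O)O)cc1C` has not yet been measured in this assay. It differs from compound 1 in one place: cycloheptyl in place of oxan-4-yl on an amide-type nitrogen. Within the data shown here, no measured pair of compounds shows a change of this kind, so the size of the step has to be guessed from compound 1 alone. The expected step is a 1.5-fold lower number from compound 1 to compound 3 (0.16 log units; within the scatter), a modest move toward a lower number, and quite possibly none beyond the scatter at all. The estimate for compound 3 in this assay is 20000 nM. The range for compound 3 is expected to run from 8000 nM to 50000 nM.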

Compound 3, half-maximal cytotoxic concentration: 7700 nM
The estimate for compound 3 lay 2.6-fold (0.41 log units) above the measured number; measured number below the stated range.
By their numbers in this assay, from the lowest: compound 3; then compounds 1 and 2 (each within the scatter of the next).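

Compounds 1 and 2 differ in more than one place, so until now no single change could be read at the amide-type nitrogen. In this assay, cycloheptyl in place of oxan-4-yl gives a 3.8-fold lower number from compound 1 to compound 3 (0.58 log units; beyond the scatter), which shows that the group on this nitrogen can shift the number beyond the scatter while the rest of the core of compound 1 stays the same. The two groups differ both in ring size and in the ring oxygen, which is the hydrogen-bond acceptor of oxan-4-yl, and no available evidence explains the step or separates these two differences.

From the compounds shown here alone, it remains open whether an oxepan-4-yl group, which keeps the seven-membered ring and restores a ring oxygen, or a piperidin-4-yl group, which carries a ring amine, would give a number close to that of compound 3 or to that of compound 1 on the same nitrogen. The compounds also leave open whether the same exchange would produce a step of similar size on the core of compound 2, since this single pair cannot show whether the change carries over.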